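This account rests on a few compounds, and the source may have more. Where it says the series, first, only, none or still open, it means among the compounds named here.

Measured so far:
compound 1 `COc1cc(-c2cc(/C=C/C(=O)c3ccc(Cl)c(Cl)c3)[nH]n2)cc(OC)c1OC` — 5%
compound 2 `COc1ccc(-c2cc(/C=C/C(=O)c3ccc(N)cc3)[nH]n2)cc1OC` — 2%

In a functional assay on NCI/ADR-RES cells (Homo sapiens) for cytotoxicity, read by sulforhodamine B assay, with a stated time of 48 h, tested at 100 uM (on this read-out lower numbers stand for a stronger effect and higher numbers for a weaker effect at the one concentration tested), compound 1 gives 5% and compound 2 gives 2%; the two numbers lie within the scatter of each other, so compound 1 stands level with compound 2. Compound 3 `COc1cc(-c2cc(/C=C/C(=O)c3ccc(F)c(F)c3)[nH]n2)cc(OC)c1OC` is not yet measured. It differs from compound 1 in one place: 3,4-difluorophenyl in place of 3,4-dichlorophenyl on a carbonyl carbon. For the measured compounds named here, no measured step of this kind exists, so in this assay only a small step is expected, none beyond the scatter or at most a modest weakening. Compound 3 is therefore expected to give 8%, in the range 2% to 25%, an estimated step of a number 3 percentage points higher from compound 1 to compound 3 (within the scatter).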

Compound 3, a percentage reported as activity, at one concentration (the size of the read-out at that concentration, not a potency): -5%
The estimate for compound 3 lay 13 percentage points above the measured number, outside the stated range (below it).
By their numbers in this assay, from the lowest: compounds 3, 2 and 1 (each within the scatter of the next).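

In this assay, the step from 3,4-dichlorophenyl to 3,4-difluorophenyl on the carbonyl carbon reads a number 10 percentage points lower from compound 1 to compound 3 (within the scatter). At this position, then, the two halogen pairs cannot be told apart on this read-out, and compound 3, at -5%, stands with compound 1 in the strongly active range.

Still open, as far as these compounds go, is whether a plain phenyl or a phenyl bearing a carboxylic acid at this place would keep so strong an effect. A single concentration also gives no potency order within the series, and no measurement at hand explains the reading.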